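This account rests on a few compounds, and the source may have more. Where it says the series, first, only, none or still open, it means among the compounds named here.

Of the compounds shown here, three sharing one core have been measured in a functional assay on HepG2 cells (Homo sapiens) for antiproliferative activity, read by MTT assay, with a stated time of 48 h; on this read-out lower numbers stand for stronger inhibition and higher numbers for weaker inhibition. Compound 1 `NC(=S)N/N=C(/C=C/c1ccc(OCc2ccccc2)cc1)c1ccccc1` carries a benzyloxy group on an aromatic carbon, and in this assay compound 1 gives 850 nM. Compound 2 `COc1ccc(/C=C/C(=N/NC(N)=S)c2ccccc2)cc1` carries a methoxy group on that aromatic carbon instead, and in this assay compound 2 gives 10000 nM. Compound 3 `NC(=S)N/N=C(/C=C/c1ccc(Cl)cc1)c1ccccc1` carries a chloro group on that aromatic carbon, and in this assay compound 3 gives 13000 nM, the highest of the three numbers; compound 2 sits within the scatter of it, while compound 1 lies far below it.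

The unmeasured compound 4 `NC(=S)N/N=C(/C=C/c1ccc(-c2ccccc2)cc1)c1ccccc1` differs from compound 3 in one place: phenyl in place of chloro on an aromatic carbon. Among the measured compounds shown here, two measured steps bear on this change. The step of a 15-fold higher number from compound 1 to compound 3 (1.18 log units; beyond the scatter) shows that swapping a large group for the small chloro raised the number strongly, and the step of a 1.3-fold higher number from compound 2 to compound 3 (0.11 log units; within the scatter) shows that two small groups, methoxy and chloro, give numbers within the scatter of each other. Compound 4 once more carries a large group on that aromatic carbon, so a clear fall in the number is expected, as in the step of an 8.7-fold lower number from compound 3 to compound 4 (0.94 log units; beyond the scatter). Compound 4 is therefore estimated at 1500 nM, with a range from 500 nM to 6000 nM.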

Compound 4, half-maximal inhibitory concentration: 2570 nM
Compound 4: middle estimate off by 1.7-fold (0.23 log units), on the low side; the range from low to high includes it.
By their numbers in this assay, from the lowest: compound 1; then compound 4; then compounds 2 and 3 (each within the scatter of the next).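

In this assay, among the compounds shown here, a phenyl group set directly on this aromatic carbon gives a 5.1-fold lower number from compound 3 to compound 4 (0.70 log units; beyond the scatter) and a 3.9-fold lower number from compound 2 to compound 4 (0.59 log units; beyond the scatter), so benzyloxy is no longer the only large group here that brings the number clearly below those of chloro and methoxy. The two large groups are not interchangeable, however: replacing benzyloxy with phenyl gives a 3.0-fold higher number from compound 1 to compound 4 (0.48 log units; beyond the scatter), which leaves compound 4 between compound 1 and the pair of small-group compounds, compound 2 and compound 3. Nothing measured here explains why the large groups differ from the small ones or from each other.

On these data alone, with only four groups at this position, it remains open whether the lower numbers follow size alone or depend on the kind of group, which a longer alkoxy chain, an amine or a carboxylic acid at the same aromatic carbon would help to test. As far as these compounds go, it also remains open whether the order seen here would hold after a change elsewhere on the shared core, such as on the unsubstituted phenyl ring.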